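Ethoxy for Chloro on a Shared Indole Thioether Core

This account rests on a few compounds, and the source may have more. Where it says the series, first, only, none or still open, it means among the compounds named here.

compound 1 `COc1ccccc1Sc1c[nH]c2ccc(Cl)cc12` — 17500 nM
compound 2 `Clc1ccc2[nH]cc(Sc3ccccc3)c2c1` — > 200000 nM
compound 3 `COC(=O)c1[nH]c2ccc(Cl)cc2c1Sc1ccccc1OC` — > 200000 nM

Three measured compounds share one core. In an assay on isolated protein for inhibition of Indoleamine 2,3-dioxygenase 1 (Homo sapiens), read by HPLC, with a stated time of 60 min, in the presence of a further agent that is not named here (a higher number here means a weaker inhibitor, a lower number a stronger inhibitor), compound 1 gives 17500 nM. Compound 2 reaches only the limit of this assay, > 200000 nM. Compound 3 likewise reaches only the limit, > 200000 nM. Among the compounds with values here, compound 1 therefore holds the only number among the three; the other two sit at the limit of > 200000 nM in this assay, at which 2 of the 3 values shown sit. The step of an at least 11-fold higher number from compound 1 to compound 2 (1.05 log units; beyond the scatter) and the step of an at least 11-fold higher number from compound 1 to compound 3 (1.05 log units; beyond the scatter) are both large losses from compound 1.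

Compound 4 `CCOc1ccc2[nH]cc(Sc3ccccc3OC)c2c1` differs from compound 1 in one place: ethoxy in place of chloro on an aromatic carbon. Neither measured step touches the chloro position, so neither bears directly on this change. Both, however, show that a single change elsewhere on the shared core can push the value past the limit, so a shift in this assay beyond the scatter, most likely toward a higher number, seems the more probable outcome, while the direction remains uncertain. Compound 4 is expected to give about 35000 nM in this assay, within 8000 nM to 200000 nM. The expected step is a 2.0-fold higher number from compound 1 to compound 4 (0.30 log units; within the scatter).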

Compound 4, half-maximal inhibitory concentration: > 200000 nM
Compound 4 gave a limit, no number; the forecaster's own chance of this, stated with the estimate: 30%; at least 5.7-fold (0.75 log units) between middle value and limit.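

At this position, which neither earlier step touched, ethoxy in place of chloro on an aromatic carbon brings an at least 11-fold higher number from compound 1 to compound 4 (1.05 log units; beyond the scatter) in this assay. Compound 4 reaches only a limit of the assay, not a number, so the full size of this loss cannot be read. The position carrying the chloro is therefore no more forgiving of this change than the two places changed earlier, and the measurable value of compound 1 now stands alone: the limit of > 200000 nM in this assay, at which 3 of the 4 values shown sit.

Going by these compounds, whether the loss follows from the ethoxy oxygen or from its two carbons stays open, since the chloro was exchanged for both at once. Equally open, on these data alone, is whether a methyl, a fluoro or an amine at this position would keep a measurable value in this assay.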